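The compounds below may be only part of what the source reports. "The series", "measured", "known", "first", "only" and "open" are said of these compounds alone.

Measured in a functional assay on LNCaP cells (Homo sapiens) for antiproliferative activity; a lower number here means a stronger inhibitor, a higher number a weaker inhibitor:
- Compound 1 `Cn1ncc(Cl)c1-c1cc(C(=O)N[C@@H]2CN[C@H](CCn3cncn3)C[C@H]2c2ccc(Cl)c(Cl)c2)oc1Cl`: 60 nM
- Compound 2 `Cn1ncc(Cl)c1-c1cc(C(=O)N[C@@H]2CN[C@H](CCO)C[C@H]2c2ccc(F)c(F)c2)oc1Cl`: 60 nM
- Compound 3 `C=CC[C@@H]1C[C@@H](c2ccc(Cl)c(Cl)c2)[C@H](NC(=O)c2cc(-c3c(Cl)cnn3C)c(Cl)o2)CN1`: 160 nM

Compound 3 has the highest number of the three, and the other two sit lower by the same margin. Compound 4 `Cn1ncc(Cl)c1-c1cc(C(=O)N[C@@H]2CN[C@H](CCO)C[C@H]2c2ccc(Cl)c(Cl)c2)oc1Cl` follows from compound 3 by hydroxymethyl in place of vinyl on a saturated chain carbon bound to a saturated ring carbon, or allyl to 2-hydroxyethyl. Among the compounds with values here, the one measured step at this place, a 2.7-fold higher number from compound 1 to compound 3 (0.43 log units; beyond the scatter), is modest. The 2-hydroxyethyl also stands in compound 2 at 60 nM, but that compound differs elsewhere as well. A modest step to a lower number is therefore expected in this assay, a 2.7-fold lower number from compound 3 to compound 4 (0.43 log units; beyond the scatter). The estimated value for compound 4 is 60 nM, with an expected range of 25 nM to 130 nM.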

Compound 4, half-maximal inhibitory concentration: 160 nM
Compound 4: the middle estimate sits 2.7-fold (0.43 log units) below what was measured; measured number outside the range, above it.
By their numbers in this assay, from the lowest: compounds 1 and 2 (each within the scatter of the next); then compounds 3 and 4 (each within the scatter of the next).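

In this assay, hydroxymethyl in place of vinyl on a saturated chain carbon bound to a saturated ring carbon gives no change at the digits printed from compound 3 to compound 4 (within the scatter) even though a hydrogen-bond donor and acceptor enter, while hydroxy in place of 1H-1,2,4-triazol-1-yl gives a 2.7-fold higher number from compound 1 to compound 4 (0.43 log units; beyond the scatter) and so separates these two chain ends. A second place also moves the number: 3,4-dichlorophenyl in place of 3,4-difluorophenyl gives a 2.7-fold higher number from compound 2 to compound 4 (0.43 log units; beyond the scatter) with the 2-hydroxyethyl chain held constant. No available evidence bears on these steps.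

On these data alone, whether an amine, a carboxylic acid or a longer chain at this position would match the triazolyl or the hydroxy compound remains open.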